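Working notes: from compound 2 to compound 4

This account rests on a few compounds, and the source may have more. Where it says the series, first, only, none or still open, it means among the compounds named here.

- compound 1 `COc1ccc(C(=O)ON=C2CC(c3ccc(O)c(OC)c3)N(C)C(c3ccc(O)c(OC)c3)C2)cc1`: 40000 nM
- compound 2 `COc1cc(C2CC(=NOC(=O)c3ccc(Cl)cc3)CC(c3ccc(O)c(OC)c3)N2C)ccc1O`: 121000 nM
- compound 3 `COc1cc(C2CC(=NOC(=O)c3ccccc3O)CC(c3ccc(O)c(OC)c3)N2C)ccc1O`: 24100 nM

All three values come from a functional assay on microsomes from liver (Rattus norvegicus, strain Wistar) for inhibition, read by spectrophotometry, with a stated time of 60 min; a higher number here means a weaker inhibitor, a lower number a stronger inhibitor. Compound 2 stands highest of the three, and both of its steps to the other compounds lie beyond the scatter. Compound 4 `COc1cc(C2CC(=NOC(=O)c3ccc([N+](=O)[O-])cc3)CC(c3ccc(O)c(OC)c3)N2C)ccc1O` has not yet been measured. It differs from compound 2 by nitro in place of chloro on an aromatic carbon, para to a large group: nitro in place of chloro on an aromatic carbon.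

Among the measured compounds shown here, no measured compound carries nitro, so the evidence is indirect. The closest step is a 3.0-fold higher number from compound 1 to compound 2 (0.48 log units; beyond the scatter), with chloro in place of methoxy on an aromatic carbon. The step of a 5.0-fold lower number from compound 2 to compound 3 (0.70 log units; beyond the scatter) also replaces 4-chlorophenyl, although it introduces 2-hydroxyphenyl. Both are modest, and both place compound 2 above the other compound. The step of a 1.7-fold lower number from compound 1 to compound 3 (0.22 log units; within the scatter) shows that the two compounds without chloro stay within the scatter of each other. For the measured compounds named here, a modest move to a lower number is therefore expected in this assay, though this rests on only three compounds. The expected change is a 2.2-fold lower number from compound 2 to compound 4 (0.34 log units; beyond the scatter). The estimated value for compound 4 is 55000 nM, with an expected range of 18000 nM to 130000 nM.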

Compound 4, half-maximal inhibitory concentration: 82000 nM
Compound 4: the middle estimate sits 1.5-fold (0.17 log units) below what was measured; the measured number falls inside the stated range.
By their numbers in this assay, from the lowest: compounds 3 and 1 (each within the scatter of the next); then compounds 4 and 2 (each within the scatter of the next).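

In this assay, nitro in place of chloro on this aromatic carbon, para to a large group, gives a 1.5-fold lower number from compound 2 to compound 4 (0.17 log units; within the scatter), so the larger nitro, with its two hydrogen-bond acceptors, is not separated from chloro here. The other two new steps, a 3.4-fold higher number from compound 3 to compound 4 (0.53 log units; beyond the scatter) and a 2.1-fold higher number from compound 1 to compound 4 (0.31 log units; beyond the scatter), show that nitro also stays apart from 2-hydroxyphenyl and methoxy, so across these four compounds the 4-chlorophenyl and 4-nitrophenyl compounds form one pair and compounds 1 and 3 the other. No measurement at hand explains this grouping.

Open, on these data alone, is whether an amine or a carboxylic acid at this position would fall with the chloro and nitro pair or with compounds 1 and 3. Also open, as far as these compounds go, is whether 4-hydroxyphenyl would track 2-hydroxyphenyl or the other 4-substituted groups.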